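The source may hold more compounds than are shown below. What is called first, only, known or untested is meant among the compounds shown, and "the series" means these compounds.

Measured so far:
compound 1 `CCc1ccccc1OC1CCN(c2ccc(-n3ccnc3)nn2)CC1` — 4 nM
compound 2 `CC(=O)c1ccccc1OC1CCN(c2ccc(-n3ccnc3)nn2)CC1` — 34 nM

In an assay on microsomes from liver for inhibition of acyl-CoA desaturase 1 (Rattus norvegicus) (a lower number here means a stronger inhibitor, a higher number a weaker inhibitor), compound 2 gives 34 nM, the higher of the two numbers measured; its nearest neighbour is compound 1, which in this assay gives 4 nM. Within the data shown here, the one step measured between them, an 8.5-fold higher number from compound 1 to compound 2 (0.93 log units; beyond the scatter), is acetyl in place of ethyl on an aromatic carbon, and it lies beyond the scatter.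

Compound 3 `COc1ccccc1OC1CCN(c2ccc(-n3ccnc3)nn2)CC1` has not yet been measured. It differs from compound 2 in one place: methoxy in place of acetyl on an aromatic carbon. Among the measured compounds shown here, the only measured step that bears on this change is an 8.5-fold higher number from compound 1 to compound 2 (0.93 log units; beyond the scatter), which shows that replacing ethyl by acetyl raised the number. Methoxy, like ethyl, is a small group without the carbonyl of acetyl, so a partial return toward the number of compound 1 is expected in this assay, though the two groups are not the same and the size of the step is uncertain.

For compound 3 the expected step is a 3.4-fold lower number from compound 2 to compound 3 (0.53 log units; beyond the scatter), a lower number than compound 2 in this assay. Compound 3 is estimated at 10 nM, in the range 3 nM to 35 nM.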

Compound 3, half-maximal inhibitory concentration: 543 nM
Compound 3: middle estimate off by 54-fold (1.73 log units), on the low side; measured number above the stated range.
By their numbers in this assay, from the lowest: compound 1; then compound 2; then compound 3.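

In this assay, among these compounds, the step of a 16-fold higher number from compound 2 to compound 3 (1.20 log units; beyond the scatter) runs against the direction suggested by the first pair of compounds: losing the double bond of acetyl does not bring the number back toward that of compound 1, and methoxy instead gives the highest number of the three. The step of a 140-fold higher number from compound 1 to compound 3 (2.13 log units; beyond the scatter) shows that this aromatic carbon separates two small groups far more sharply than the first step implied, and acetyl and methoxy, which each count one hydrogen-bond acceptor, still differ beyond the scatter, so that count does not follow the numbers here. No measurement available here accounts for why methoxy stands so far from ethyl and acetyl.

Going by these compounds, what remains open is whether the number follows the atom that joins the group to the aromatic ring, since methoxy joins through oxygen and the other two through carbon, or the size and shape of the group as a whole. Ethoxy, a propyl chain or an amine at this position could separate those readings, and the three compounds shown cannot say how any of them would behave.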